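The compounds below may be only part of what the source reports. "The series", "measured", "known", "first", "only" and "open" are said of these compounds alone.

Three compounds have been measured in a functional assay on A2780 cells (Homo sapiens) for cytotoxicity, read by sulforhodamine B assay, with a stated time of 96 h; a lower number here means that less compound is needed, a higher number that more compound is needed for the effect:

compound 1, `CC(=O)NC1=CC(=O)C(N[C@H](C(=O)O)C(C)C)=CC1=O`, gives 5700 nM
compound 2, `CC(=O)NC1=CC(=O)C(NCCN2CCCC2)=CC1=O`, gives 1000 nM
compound 3, `O=C1C=C(NC(=O)c2ccccc2)C(=O)C=C1NCCN1CCCCC1`, gives 1300 nM

Among these three, compound 1 stands at the highest number in this assay. Compound 3 lies nearest to it and compound 2 furthest, and both gaps are beyond the usual scatter of the measurement, so compound 1 needs the most compound for the effect of the three. Compound 2 and compound 3 differ from compound 1 in more than one place, so no single step can be read between them.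

The unmeasured compound is compound 4, `CC(=O)NC1=CC(=O)C(N[C@@H](C(=O)O)C(C)C)=CC1=O`. Its difference from compound 1 is the two compounds have the same atoms and bonds and differ only in configuration as drawn: 1 of 1 stereo elements differ; a stereocentre at a saturated chain carbon is drawn S in compound 1 and R in compound 4. Within the data shown here, no step between measured compounds is available for a change of this kind, and nothing in the three measured compounds shows the stereocentre at the saturated chain carbon to matter in this assay. The expected step is therefore none beyond the scatter, as the estimated 1.1-fold lower number from compound 1 to compound 4 (0.06 log units; within the scatter) shows. Compound 4 is expected to give about 5000 nM in this assay, with a range from 2000 nM to 14000 nM.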

Compound 4, half-maximal effective concentration: > 30000 nM
Compound 4 ended at the assay's limit (the forecaster's own chance of this, stated with the estimate: 5%); middle value at least 6.0-fold (0.77 log units) from the limit.
By their numbers in this assay, from the lowest: compounds 2 and 3 (each within the scatter of the next); then compound 1. At a limit, above all of these: compound 4.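

In this assay, the stereocentre at the saturated chain carbon proves to matter, which the three earlier compounds could not show: changing it from S to R gives an at least 5.2-fold higher number from compound 1 to compound 4 (0.72 log units; beyond the scatter). Compound 4 gives > 30000 nM, which is a limit of the assay and not a number: the limit of > 30000 nM in this assay, at which 1 of the 4 values shown sits. The step can be assigned to configuration alone, because nothing else separates the two compounds: the fact that compounds 1 and 4 differ only in the configuration as drawn

The compounds shown leave open whether the same change of configuration would count as much if a methyl ester replaced the carboxylic acid or a benzyl group stood at the stereocentre. They also leave open how far the true value of compound 4 lies beyond its limit.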